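The source may report more compounds than this note shows. Statements on the series, on what has been measured and on what is new or still open speak of the compounds shown alone.

In a functional assay on CCRF-CEM cells (Homo sapiens) for antiproliferative activity (on this read-out higher numbers stand for weaker inhibition of growth and lower numbers for stronger inhibition of growth), the measured compounds are:

- Compound 1 `COC(=O)CCCCCCCCCCCCCC/C=C1\CC(CO)(COC(=O)C(C)(C)C)OC1=O` gives 0.691 ug/mL
- Compound 2 `CCCCCCCCC(O)CCCCCC/C=C1\CC(CO)(COC(=O)C(C)(C)C)OC1=O` gives 5.72 ug/mL
- Compound 3 `CCCCCOCCCCCCC/C=C1\CC(CO)(COC(=O)C(C)(C)C)OC1=O` gives 0.877 ug/mL

On these numbers, compound 3 stands level with compound 1 (a 1.3-fold higher number from compound 1 to compound 3 (0.10 log units; within the scatter)) and well apart from compound 2 (a 6.5-fold lower number from compound 2 to compound 3 (0.81 log units; beyond the scatter)).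

Compound 4 `CC(C)(C)C(=O)OCC1(CO)C/C(=C\CCCCCCCCCCCCCCC=O)C(=O)O1` differs from compound 3 in one place: 7-formylheptyl in place of pentyloxy on a saturated chain carbon, seven bonds along the chain from a double-bonded chain carbon In words, 7-formylheptyl replaces pentyloxy on a saturated chain carbon, seven bonds along the chain from a double-bonded chain carbon.

Within the data shown here, two measured steps bear on this change. The closer guide is compound 1, which carries 7-(methoxycarbonyl)heptyl at that place. Like 7-formylheptyl, this group holds a carbonyl, and its exchange for pentyloxy stayed within the scatter (a 1.3-fold higher number from compound 1 to compound 3 (0.10 log units; within the scatter)). Among the measured compounds shown here, the other guide is compound 2, which carries 1-hydroxynonyl and gave the only step beyond the scatter (a 6.5-fold lower number from compound 2 to compound 3 (0.81 log units; beyond the scatter)). Compound 4 has no such hydroxy group, so that larger step offers little guidance here. For the measured compounds named here, no measured compound carries the formyl group itself, so this comparison is only a read-across.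

The expected result in this assay is therefore no change beyond the scatter: a 1.1-fold lower number from compound 3 to compound 4 (0.04 log units; within the scatter) is the estimated step. For compound 4 the estimated value is 0.8 ug/mL with an expected range of 0.25 ug/mL to 2.5 ug/mL for the measurement.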

Compound 4, concentration for 50% growth inhibition: 0.933 ug/mL
The estimate for compound 4 lay 1.2-fold (0.07 log units) below the measured number, and the stated range covers the measured number.
By their numbers in this assay, from the lowest: compounds 1, 3 and 4 (each within the scatter of the next); then compound 2.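

In this assay, compound 4 shows that 7-formylheptyl can stand on this saturated chain carbon, seven bonds along the chain from a double-bonded chain carbon, with the number staying within the scatter of the pentyloxy compound (a 1.1-fold higher number from compound 3 to compound 4 (0.03 log units; within the scatter)). It also adds a direct comparison on the carbonyl carbon: hydrogen in place of methoxy again stays within the scatter (a 1.4-fold higher number from compound 1 to compound 4 (0.13 log units; within the scatter)), so this assay separates neither the formyl nor the methyl ester end from the pentyloxy compound. Compound 2 remains clearly apart from the formyl compound as well (a 6.1-fold lower number from compound 2 to compound 4 (0.79 log units; beyond the scatter)), a step beyond the scatter, and no measurement offered here explains any of these results.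

The compounds shown leave open whether a carboxylic acid or an amine in place of the formyl group would also stay within the scatter. They also leave open whether the hydroxy group of 1-hydroxynonyl alone accounts for the gap to compound 2, as that group and the rest of the chain change together in the step to compound 4.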